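The source may hold more compounds than are shown below. What is called first, only, known or untested is meant among the compounds shown, and "the series" means these compounds.

In a functional assay on MCF7 cells (Homo sapiens) for antiproliferative activity (on this read-out higher numbers stand for weaker inhibition and lower numbers for stronger inhibition), compound 2 `CC(C)=CCc1cc(C(=O)Nc2cc3ccc(OCCCNCc4ccccc4)c(C)c3oc2=O)ccc1O` gives 910 nM, within the scatter of compound 1 `CC(C)=CCc1cc(C(=O)Nc2cc3ccc(OCCC4CCCCN4)c(C)c3oc2=O)ccc1O` at 710 nM. Compound 3 `CC(C)=CCc1cc(C(=O)Nc2cc3ccc(OCCCNC(C)(C)c4ccccc4)c(C)c3oc2=O)ccc1O` carries 1-methyl-1-phenylethyl in place of benzyl on an amine nitrogen, which places 1-methyl-1-phenylethyl in place of benzyl on an amine nitrogen. For the measured compounds named here, the only measured step, a 1.3-fold higher number from compound 1 to compound 2 (0.11 log units; within the scatter), exchanges piperidin-2-yl for (benzylamino)methyl, so it bears on this change only loosely and no measured step tests the new group directly. The change expected in this assay is therefore none beyond the scatter, with an estimated 1.1-fold higher number from compound 2 to compound 3 (0.04 log units; within the scatter). For compound 3 the estimated value is 1000 nM, with an expected range from 420 nM to 2400 nM.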

Compound 3, half-maximal inhibitory concentration: 1070 nM
Estimate against measurement, compound 3: 1.1-fold (0.03 log units) below; measured number inside the range.
By their numbers in this assay, from the lowest: compounds 1, 2 and 3 (each within the scatter of the next).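

In this assay, 1-methyl-1-phenylethyl in place of benzyl on an amine nitrogen gives a 1.2-fold higher number from compound 2 to compound 3 (0.07 log units; within the scatter), so this position accepts a group of 9 heavy atoms in place of one of 7 with no shift beyond the scatter. Replacing the piperidin-2-yl of compound 1 with ((1-methyl-1-phenylethyl)amino)methyl gives a 1.5-fold higher number from compound 1 to compound 3 (0.18 log units; within the scatter), which is also no shift beyond the scatter. No supporting evidence bears on this result. The compounds shown leave open whether an acetyl group on this amine nitrogen, or a cyclohexyl ring in place of the phenyl ring, would move the number beyond the scatter.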